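Urea series: indazole replacement, cytotoxicity working notes

The compounds below may be only part of what the source reports. "The series", "measured", "known", "first", "only" and "open" are said of these compounds alone.

compound 1 `O=C(Nc1ccc(-n2ncc3c(Cl)cccc32)cc1)Nc1ccc(Cl)c(C(F)(F)F)c1` — 3100 nM
compound 2 `O=C(Nc1ccc(-n2ncc3c(C(F)(F)F)cccc32)cc1)Nc1ccc(C(F)(F)F)cc1` — 800 nM

Both compounds were read in a functional assay on A549 cells (Homo sapiens) for cytotoxicity, read by MTT assay, with a stated time of 72 h; a lower number here means a stronger inhibitor, a higher number a weaker inhibitor. Compound 1 carries the highest number of the two; compound 2 sits at a lower number, and the gap between them lies beyond the scatter. Compound 3 `O=C(Nc1ccc(-n2ncc3ccncc32)cc1)Nc1ccc(Cl)c(C(F)(F)F)c1` is not yet measured. It differs from compound 1 by a group of 9 heavy atoms (6 carbon, 3 nitrogen; one five-membered aromatic ring with 2 hetero atoms, one six-membered aromatic ring with 1 hetero atom) in place of a group of 10 heavy atoms (7 carbon, 2 nitrogen, 1 chlorine; one five-membered aromatic ring with 2 hetero atoms, one six-membered aromatic ring of carbon only), on an aromatic carbon. For the measured compounds named here, no measured pair shows this change, so nothing in the numbers so far speaks for a direction. The expected step, a 1.0-fold lower number from compound 1 to compound 3 (0.01 log units; within the scatter), is therefore no step beyond the scatter. Compound 3 is estimated at 3000 nM, with a range from 1000 nM to 9000 nM.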

Compound 3, half-maximal inhibitory concentration: 10600 nM
For compound 3 the middle estimate is 3.5-fold (0.55 log units) below the measured one; the whole stated range lies below it.
By their numbers in this assay, from the lowest: compound 2; then compound 1; then compound 3.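

In this assay, putting the group with a hetero atom in its six-membered aromatic ring in place of 4-chloro-1H-indazol-1-yl, para to a large group, gives a 3.4-fold higher number from compound 1 to compound 3 (0.53 log units; beyond the scatter). This is the only single-place step among the compounds shown, and it shows that this position responds to the change, with a weaker result. Nothing measured alongside accounts for the step.

The step combines loss of the chlorine with gain of a ring nitrogen, and the two remain unseparated. As far as these compounds go, whether an unsubstituted 1H-indazol-1-yl group, or an amine on the entering group, would recover activity stays open.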